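A few compounds are considered here, and "the series" means these few. Any claim that something is new, unique, unknown or untested is made for them only; others in the source may bear on it.

Measured compounds in an assay on isolated protein for inhibition of tyrosine-protein kinase receptor UFO (Homo sapiens), read by FRET and Z'-LYTE, with a stated time of 1.5 h; on this read-out higher numbers stand for weaker inhibition and lower numbers for stronger inhibition:
- compound 1 `Cc1ccc2c(c1)c(=O)c(C(=O)Nc1ccc(Oc3ncnc4[nH]cc(-c5ccccc5)c34)c(F)c1)c(C)n2C`: 100 nM
- compound 2 `Cc1c(C(=O)Nc2ccc(Oc3ncnc4[nH]cc(-c5ccccc5)c34)c(F)c2)c(=O)c2cc(C3CCCC3)ccc2n1C`: 200 nM
- compound 3 `Cc1c(C(=O)Nc2ccc(Oc3ncnc4[nH]cc(-c5ccccc5)c34)c(F)c2)c(=O)c2cc(C3=CCCC3)ccc2n1C`: 3320 nM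

Compound 3 has the highest number of the three; the steps of a 33-fold higher number from compound 1 to compound 3 (1.52 log units; beyond the scatter) and a 17-fold higher number from compound 2 to compound 3 (1.22 log units; beyond the scatter) are both beyond the scatter, whereas a 2.0-fold higher number from compound 1 to compound 2 (0.30 log units; within the scatter) is within it. Compound 4 `Cc1c(C(=O)Nc2ccc(Oc3ncnc4[nH]cc(-c5ccccc5)c34)c(F)c2)c(=O)c2cc(OC(F)(F)F)ccc2n1C` differs from compound 3 by trifluoromethoxy in place of cyclopent-1-en-1-yl on an aromatic carbon. Among the compounds with values here, no measured step introduces trifluoromethoxy at this position, so the estimate rests on the comparison above: the two saturated or acyclic substituents sit close together, and only cyclopent-1-en-1-yl carries the large loss. Compound 4 is therefore expected to move back toward those values, a step of an 11-fold lower number from compound 3 to compound 4 (1.04 log units; beyond the scatter) in this assay, though with wide uncertainty. For compound 4 the expected value is 300 nM, within a range of 80 nM to 1500 nM.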

Compound 4, half-maximal inhibitory concentration: 74 nM
Beside the measured number, compound 4's estimate is 4.1-fold (0.61 log units) above it, and the stated range ends above it.
By their numbers in this assay, from the lowest: compounds 4, 1 and 2 (each within the scatter of the next, the first and the last beyond it); then compound 3.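

In this assay, trifluoromethoxy at this position shows that the loss seen with cyclopent-1-en-1-yl is not shared by every substituent of five heavy atoms (a 45-fold lower number from compound 3 to compound 4 (1.65 log units; beyond the scatter)). Against cyclopentyl the change is modest but beyond the scatter (a 2.7-fold lower number from compound 2 to compound 4 (0.43 log units; beyond the scatter)), whereas against methyl it stays within the scatter (a 1.4-fold lower number from compound 1 to compound 4 (0.13 log units; within the scatter)). No available evidence accounts for these differences.

As far as these compounds go, whether an amine, a carboxylic acid or a longer alkyl chain at this position stays close to compound 4 remains open. Also open, from the compounds shown here alone, is whether the loss extends to other rings carrying a double bond, such as cyclohexenyl.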